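Aryl amines on the shared core: chloro removal at the pendant phenyl

The compounds below may be only part of what the source reports. "The series", "measured", "known", "first", "only" and "open" are said of these compounds alone.

Measured compounds:
- compound 1, `Nc1cccc(-c2cn3c(-c4ccc(Cl)cc4)csc3n2)c1`: 17000 nM
- compound 2, `C=C(Br)C(=O)Nc1cccc(-c2cn3nc(Cc4ccc(OC)cc4)sc3n2)c1`: 2300 nM
- compound 3, `C=C(Br)C(=O)Nc1cccc(-c2cn3nc(-c4cccs4)sc3n2)c1`: 670 nM

In a functional assay on HeLa cells (Homo sapiens) for inhibition, read by cell counting, with a stated time of 4 days (on this read-out lower numbers stand for stronger inhibition and higher numbers for weaker inhibition), compound 1 gives 17000 nM, the highest of the three numbers. Compound 2 gives 2300 nM and compound 3 gives 670 nM, so compound 1 stands weakest of the measured set, with both gaps beyond the scatter.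

Among the compounds with values here, the only measured step, a 3.4-fold lower number from compound 2 to compound 3 (0.54 log units; beyond the scatter), concerns a substituent on a different part of the scaffold than the one changed here and is read as modest. It is not a model for the step to compound 4.

Compound 4, `Nc1cccc(-c2cn3c(-c4ccccc4)csc3n2)c1`, differs from compound 1 by hydrogen in place of chloro on an aromatic carbon. Within the data shown here, no measured pair in the set isolates a chloro-to-hydrogen exchange at this place, so the size of the step is uncertain. The working expectation is that compound 4 stays close to compound 1, with at most a small drift toward a higher number, a step of a 1.5-fold higher number from compound 1 to compound 4 (0.17 log units; within the scatter) that is expected to lie near or just beyond the usual scatter.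

Compound 4 is therefore estimated at 25000 nM in this assay, in the range 8000 nM to 70000 nM.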

Compound 4, half-maximal inhibitory concentration: 60000 nM
Estimate against measurement, compound 4: 2.4-fold (0.38 log units) below; the measured number falls inside the stated range.
By their numbers in this assay, from the lowest: compound 3; then compound 2; then compound 1; then compound 4.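

In this assay, the change from 4-chlorophenyl to phenyl gives a 3.5-fold higher number from compound 1 to compound 4 (0.55 log units; beyond the scatter), a step beyond the scatter. Within the data shown here, this is the first reading at this place, on an aromatic carbon para to a large group, and it shows that the number responds to the loss of this single chlorine, whereas the earlier step between measured compounds concerned a substituent elsewhere on the scaffold. The data give the size and direction of this one exchange, but nothing shown explains it.

The compounds shown leave open whether the step is particular to chloro or would also be seen with fluoro, methyl, trifluoromethyl or a carboxylic acid at the same place, so a single pair gives no trend across substituents. Going by these compounds, it also remains open whether the 4-chlorophenyl to phenyl step would carry over to compounds bearing the bromoacrylamide seen in compound 2 and compound 3, since those two differ from compound 1 and compound 4 in more than one place and no direct comparison can be read.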